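The source may hold more compounds than are shown below. What is called first, only, known or untested is meant among the compounds shown, and "the series" means these compounds.

Compound 3 `CNC(=O)NCCS(=O)(=O)NC(=O)c1ccc(Nc2nc(NC3(c4ccc(Cl)cc4)CC3)nc(OCC(F)(F)F)n2)cc1` gives 40 nm/s in a physicochemical assay for permeability, using PAMPA, at pH 7.4 (on this read-out lower numbers stand for lower permeability and higher numbers for higher permeability), the second highest of the three numbers measured. Its nearest neighbour is compound 2 `CC(C)NC(=O)NCCS(=O)(=O)NC(=O)c1ccc(Nc2nc(NC3(c4ccc(Cl)cc4)CC3)nc(OCC(F)(F)F)n2)cc1`, which in this assay gives 45 nm/s; the step of a 1.1-fold lower number from compound 2 to compound 3 (0.05 log units; within the scatter) lies within the scatter. Furthest away is compound 1 `O=C(NS(=O)(=O)CCNC(=O)C1CC1)c1ccc(Nc2nc(NC3(c4ccc(Cl)cc4)CC3)nc(OCC(F)(F)F)n2)cc1`, which gives 1 nm/s; the step of a 40-fold higher number from compound 1 to compound 3 (1.60 log units; beyond the scatter) is large, as is a 45-fold higher number from compound 1 to compound 2 (1.65 log units; beyond the scatter).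

Compound 4 `Cc1ccccc1S(=O)(=O)NC(=O)c1ccc(Nc2nc(NC3(c4ccc(Cl)cc4)CC3)nc(OCC(F)(F)F)n2)cc1` differs from compound 3 by 2-methylphenyl in place of 2-((methylcarbamoyl)amino)ethyl on a sulfonyl sulfur. Within the data shown here, none of the measured steps touches this place: all three concern the group on the carbonyl carbon at the end of the 2-((methylcarbamoyl)amino)ethyl chain, which is now removed altogether. Among the measured compounds shown here, they show only that changes in this part of the molecule can move the number a long way, as in a 40-fold higher number from compound 1 to compound 3 (1.60 log units; beyond the scatter), while the exchange a 1.1-fold lower number from compound 2 to compound 3 (0.05 log units; within the scatter) hardly moved it. The direction for compound 4 is therefore not settled by the data, and the estimate is a tentative one. The step of a 3.0-fold higher number from compound 3 to compound 4 (0.48 log units; beyond the scatter) is expected to lie beyond the scatter. For compound 4 the expected value in this assay is 120 nm/s, with a range from 30 nm/s to 500 nm/s.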

Compound 4, apparent permeability: 265 nm/s
For compound 4 the middle estimate is 2.2-fold (0.34 log units) below the measured one; the measured number falls inside the stated range.
By their numbers in this assay, from the lowest: compound 1; then compounds 3 and 2 (each within the scatter of the next); then compound 4.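

In this assay, among these compounds, the earlier compounds varied only the far end of the chain on the sulfonyl sulfur, whereas compound 4 replaces the whole chain, and this gives a 6.6-fold higher number from compound 3 to compound 4 (0.82 log units; beyond the scatter) and also a 5.9-fold higher number from compound 2 to compound 4 (0.77 log units; beyond the scatter) as modest steps beyond the scatter. The entering 2-methylphenyl group has a six-membered aromatic ring of carbon only and no hydrogen-bond donors, while the 2-((methylcarbamoyl)amino)ethyl chain it replaces has no ring and carries donors, and the same exchange measured against the cyclopropyl amide chain gives a 270-fold higher number from compound 1 to compound 4 (2.42 log units; beyond the scatter) as a large step. So this position accepts an aromatic group in place of an open chain, and the number ends up beyond those of all three chain compounds, though no measured property here accounts for the rise.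

The compounds shown leave open whether the ring, its methyl group or the loss of the chain carries the step, which a plain phenyl or a simple methyl on the sulfonyl sulfur would help to separate. They also leave open how a 2-methoxyphenyl group, or a chain ending in an amine or a carboxylic acid, would read at this place.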